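Replacing an aryl group with a hydroxycyclohexenyl ring

The compounds below may be only part of what the source reports. "The series", "measured", "known", "first", "only" and "open" are said of these compounds alone.

Of the compounds shown here, two from this series have been measured. Compound 1 `C[C@@H](O[C@H]1CN2C(=O)C=C(c3ccc(CO)cc3)CC2[C@@H]1c1ccc(F)cc1)c1cc(C(F)(F)F)cc(C(F)(F)F)c1` carries a 4-(hydroxymethyl)phenyl group on a double-bonded ring carbon of the shared core; in an assay on CHO cells for displacement of a labelled ligand from Substance-P receptor (Homo sapiens), in the presence of a further agent that is not named here (a higher number here means a weaker inhibitor, a lower number a stronger inhibitor), compound 1 gives 23 nM. Compound 2 `COc1cc(C2=CC(=O)N3C[C@H](O[C@H](C)c4cc(C(F)(F)F)cc(C(F)(F)F)c4)[C@@H](c4ccc(F)cc4)C3C2)ccn1` bears a 2-methoxypyridin-4-yl group at the same place and in this assay compound 2 gives 44 nM. Among the compounds with values here, the step of a 1.9-fold higher number from compound 1 to compound 2 (0.28 log units; within the scatter) lies within the scatter, so the two values cannot be ordered; compound 2 merely has the higher of the two numbers, with compound 1 as its only neighbour.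

Compound 3 `C[C@@H](O[C@H]1CN2C(=O)C=C(C3=CCC(O)CC3)CC2[C@@H]1c1ccc(F)cc1)c1cc(C(F)(F)F)cc(C(F)(F)F)c1` has not yet been measured. It differs from compound 2 as follows: 4-hydroxycyclohex-1-en-1-yl in place of 2-methoxypyridin-4-yl on a double-bonded ring carbon. Within the data shown here, the only step known at this position, a 1.9-fold higher number from compound 1 to compound 2 (0.28 log units; within the scatter), exchanged one six-membered aromatic ring for another and moved the number little. Among the measured compounds shown here, the change to compound 3 is larger in kind, as an aromatic ring gives way to a non-aromatic one bearing a hydroxyl group, and no measured pair shows what that does here. The estimate for compound 3 in this assay is therefore 70 nM, within 20 nM to 300 nM, meaning an expected step of a 1.6-fold higher number from compound 2 to compound 3 (0.20 log units; within the scatter) that may well stay inside the scatter.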

Compound 3, half-maximal inhibitory concentration: 13 nM
The estimate for compound 3 lay 5.4-fold (0.73 log units) above the measured number; the measured number lies below the stated range.
By their numbers in this assay, from the lowest: compounds 3, 1 and 2 (each within the scatter of the next, the first and the last beyond it).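

In this assay, within the data shown here, the position on the double-bonded ring carbon accepts a non-aromatic ring: the 4-hydroxycyclohex-1-en-1-yl group gives a 3.4-fold lower number from compound 2 to compound 3 (0.53 log units; beyond the scatter), a modest change and the first step here to pass beyond the scatter. Set against the 4-(hydroxymethyl)phenyl group, the same ring gives a 1.8-fold lower number from compound 1 to compound 3 (0.25 log units; within the scatter), so compound 3 cannot be ordered against compound 1, and among these three compounds an aromatic ring at this place is shown not to be needed for a number in this range. Nothing available here accounts for the separation of compound 3 from compound 2.

The step from compound 2 to compound 3 changes several things at once, as the ring loses its aromatic character and ring nitrogen and a hydroxyl replaces the methoxy group, so the compounds shown do not divide the change among these features. They leave open whether the hydroxyl contributes at all, which a plain cyclohexenyl ring would test, and whether an amine or a carboxylic acid at the same ring carbon would be accepted in its place.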